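The compounds below may be only part of what the source reports. "The series", "measured", "known", "first", "only" and "open" are said of these compounds alone.

Compound 1 `O=C(NC[C@@H](O)C(=O)O)c1ccc(CN(C(=O)Nc2cccc(Br)c2)c2ccc(C3CCCCC3)cc2)cc1`: 1.2 h
Compound 2 `O=C(NC[C@@H](O)C(=O)O)c1ccc(CN(C(=O)Nc2cc(Br)cc(C(F)(F)F)c2)c2ccc(C3=CCCCC3)cc2)cc1`: 0.767 h

In an in vivo ADME assay on the whole organism (strain Sprague-Dawley) for metabolic stability, with Rattus norvegicus as the target, at a dose of 2 mg/kg by the intravenous route (on this read-out higher numbers stand for a longer-lived compound and lower numbers for a shorter-lived compound), compound 2 gives 0.767 h, which lies within the scatter of compound 1 at 1.2 h. Compound 3 `COc1cc(NC(=O)N(Cc2ccc(C(=O)NC[C@@H](O)C(=O)O)cc2)c2ccc(C3=CCCCC3)cc2)cc(C(F)(F)F)c1` has not yet been measured. It differs from compound 2 in one place: methoxy in place of bromo on an aromatic carbon, with methoxy in place of bromo on an aromatic carbon, meta to a trifluoromethyl group. Going by the values given here, no two measured compounds differ in only one place, so no measured step guides this change, and no shift beyond the scatter is expected. The expected change is a 1.0-fold higher number from compound 2 to compound 3 (0.02 log units; within the scatter). Compound 3 is estimated at 0.8 h, with a range of 0.4 h to 1.6 h.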

Compound 3, half-life: 0.883 h
For compound 3 the middle estimate is 1.1-fold (0.04 log units) below the measured one; measured number inside the range.
By their numbers in this assay, from the lowest: compounds 2, 3 and 1 (each within the scatter of the next).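

Putting methoxy in place of bromo on the 3-(trifluoromethyl)phenyl ring, meta to the trifluoromethyl group, gives a 1.2-fold higher number from compound 2 to compound 3 (0.06 log units; within the scatter) in this assay. In this one pair, then, half-life does not separate the two groups, even though methoxy brings a hydrogen-bond acceptor that bromo lacks. Nothing measured here speaks to why the two read alike.

On these data alone, whether an amine, a nitrile or a carboxylic acid at this position would read differently stays open. So does whether this swap would read the same on a different core.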